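Aryl ketone swap on the shared core: compound 3

A few compounds are considered here, and "the series" means these few. Any claim that something is new, unique, unknown or untested is made for them only; others in the source may bear on it.

Measured in a functional assay on HepG2 cells (Homo sapiens) for antiproliferative activity, read by MTT assay, with a stated time of 48 h; a lower number here means a stronger inhibitor, a higher number a weaker inhibitor:
- compound 1 `COc1ccc(/C=C/c2cc(OC)cc(OC)c2/C=C/C(=O)c2cccc(Cl)c2)cc1`: 9.5 ug/mL
- compound 2 `COc1ccc(/C=C/c2cc(OC)cc(OC)c2/C=C/C(=O)c2ccc(F)cc2)cc1`: 12.2 ug/mL

In this assay, compound 2 stands at 12.2 ug/mL. This is within the scatter of compound 1, so the two numbers give no order.

Compound 3 `COc1ccc(/C=C/c2cc(OC)cc(OC)c2/C=C/C(=O)c2ccccc2C)cc1` is next, with 2-methylphenyl in place of 4-fluorophenyl on a carbonyl carbon.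

Among the compounds with values here, only one measured step bears on this change. It is a 1.3-fold higher number from compound 1 to compound 2 (0.11 log units; within the scatter), made on the same carbonyl carbon. Within the data shown here, no measured compound yet carries 2-methylphenyl, so the data offer no direction for the change. Among the measured compounds shown here, with only that small step as a guide, no step beyond the scatter is expected in this assay.

The expected step is a 1.1-fold lower number from compound 2 to compound 3 (0.04 log units; within the scatter).

For compound 3 the estimated value is 11 ug/mL, with an expected range of 5 ug/mL to 24 ug/mL.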

Compound 3, half-maximal inhibitory concentration: 5.3 ug/mL
Beside the measured number, compound 3's estimate is 2.1-fold (0.32 log units) above it, and the stated range covers the measured number.
By their numbers in this assay, from the lowest: compounds 3, 1 and 2 (each within the scatter of the next, the first and the last beyond it).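

In this assay, within the data shown here, this carbonyl carbon now shows a first step beyond the scatter, for 2-methylphenyl in place of 4-fluorophenyl (a 2.3-fold lower number from compound 2 to compound 3 (0.36 log units; beyond the scatter)), so the aryl group held here can shift the number. The step is modest and does not extend to every earlier group: with 2-methylphenyl in place of 3-chlorophenyl (a 1.8-fold lower number from compound 1 to compound 3 (0.25 log units; within the scatter)), compound 1 and compound 3 cannot be put in order. Nothing measured in this series accounts for the step from compound 2 to compound 3.

Open, from the compounds shown here alone, is whether the step follows the methyl group itself or its place on the ring, a question that 3-methylphenyl or 4-methylphenyl would bear on. Also open, going by these compounds, is how an amine, a carboxylic acid or a longer chain on this aryl ring would read in this assay.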